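From pyridin-3-yl to cyclopropyl: a permeability step

A few compounds are considered here, and "the series" means these few. Any claim that something is new, unique, unknown or untested is made for them only; others in the source may bear on it.

For the measured compounds named here, in an ADME assay for permeability, using PAMPA, at pH 5.5 (a lower number here means that the compound crosses the layer more slowly, a higher number that the compound crosses the layer faster), compound 1 (`CCCCc1nc(=O)c(S(=O)(=O)c2ccc(-c3cccnc3)cc2)c(O)n1-c1c(OC)cccc1OC`) reads 202 nm/s as one of only two numbers available in this small series. Compound 3 (`CCCCc1[nH]c(=O)c(S(=O)(=O)c2ccc(-n3cc(Cl)ccc3=O)cc2)c(O)c1-c1c(OC)cccc1OC`) reads 285 nm/s in this assay and lies within the usual scatter of compound 1, so the two numbers cannot be told apart. Compound 2 (`CCCCc1[nH]c(=O)c(S(=O)(=O)c2ccc(-c3cccnc3OC)cc2)c(O)c1-c1c(OC)cccc1OC`) has "not determined" (no result reported) as its entry and contributes no number.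

Compound 4 (`CCCCc1nc(=O)c(S(=O)(=O)c2ccc(C3CC3)cc2)c(O)n1-c1c(OC)cccc1OC`) keeps the core of compound 1 and changes one group: cyclopropyl in place of pyridin-3-yl on an aromatic carbon describes the change, cyclopropyl in place of pyridin-3-yl on an aromatic carbon, para to a large group.

Going by the values given here, no measured pair isolates this change. Compound 1 and compound 3 differ in more than one place yet stay within the scatter of each other, and that comparison gives no firm direction for the step. The working expectation in this assay is therefore a small rise at most, with no step beyond the scatter anticipated. The estimate means a 1.4-fold higher number from compound 1 to compound 4 (0.14 log units; within the scatter) as an expected change that stays inside the scatter. Compound 4 is estimated at 280 nm/s in this assay with an expected range from 130 nm/s to 600 nm/s as the working bounds.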

Compound 4, apparent permeability: 615 nm/s
Beside the measured number, compound 4's estimate is 2.2-fold (0.34 log units) below it, and the stated range ends below it.
By their numbers in this assay, from the lowest: compounds 1 and 3 (each within the scatter of the next); then compound 4.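

In this assay, for the compounds shown here, cyclopropyl in place of pyridin-3-yl on an aromatic carbon, para to a large group, gives a 3.0-fold higher number from compound 1 to compound 4 (0.48 log units; beyond the scatter) and provides the first single-place comparison. Compound 1 and compound 3 differ in more than one place, so neither could isolate this position; the new pair shows that the read-out responds to the group placed there, with the three-membered carbon ring giving the higher number. Nothing available accounts for the size or direction of this step.

This single pair changes ring size, aromatic character and the ring nitrogen together, so it does not show which of these differences matters; phenyl, isopropyl or an amine at the same place would help to separate them. As far as these compounds go, it also remains open whether the same replacement would give a comparable step on the core of compound 3, and whether a longer chain at this place would read closer to compound 1 or to compound 4.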